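Adding a Methyl to the Amine of Compound 1

A few compounds are considered here, and "the series" means these few. Any claim that something is new, unique, unknown or untested is made for them only; others in the source may bear on it.

Compound 1 `O=c1cc(NCc2ccccc2)sc2c([N+](=O)[O-])cc(C(F)(F)F)cc12` was tested in an ADME assay on Vero cells (Chlorocebus sabaeus) for cytotoxicity, read by MTT assay, with a stated time of 48 h; a higher number here means a weaker inhibitor, a lower number a stronger inhibitor. In this assay compound 1 gives > 64 ug/mL, which is a limit of the assay rather than a measured number. Compound 1 therefore stands at the limit of > 64 ug/mL in this assay, at which 1 of the 2 values shown sits. Compound 2 `O=c1nc(NC2CCCCC2)oc2c([N+](=O)[O-])cc(C(F)(F)F)cc12`, built on a different core, gives 5.39 ug/mL in this assay; no single-point change connects it to compound 1, so the two values can only be set side by side.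

Compound 3 `CN(Cc1ccccc1)c1cc(=O)c2cc(C(F)(F)F)cc([N+](=O)[O-])c2s1` is not yet measured. It differs from compound 1 by methyl in place of hydrogen on a nitrogen on an aromatic ring, taking the benzylamino group to benzyl(methyl)amino. Among the measured compounds shown here, no measured pair shows what such a change does here, so the step that the limit leaves unreadable from compound 1 to compound 3 is expected to stay within the usual scatter, in no clear direction. Compound 3 is thus expected to give about 70 ug/mL, within a range from 25 ug/mL to 200 ug/mL, and the assay will most likely again report only its limit.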

Compound 3, half-maximal inhibitory concentration: > 64 ug/mL
Compound 3: a limit, no number; the forecaster's own chance of this, stated with the estimate: 70%; the middle value lies beyond the limit too.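

In this assay, compound 1 and compound 3 each give only a limit of the assay and not a number, so no step can be read between them: the limit of > 64 ug/mL in this assay, at which 2 of the 3 values shown sit. As far as these compounds go, whether methyl in place of hydrogen on that nitrogen shifts the cytotoxicity at all, and in which direction, stays open.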